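Cyclohexyl for pentyl on the acetylated oxadiazole glycoside

The source may report more compounds than this note shows. Statements on the series, on what has been measured and on what is new or still open speak of the compounds shown alone.

Compound 1 `CCCCCc1nnc(-c2ccc(O[C@@H]3O[C@H](COC(C)=O)[C@@H](OC(C)=O)[C@H](OC(C)=O)[C@H]3OC(C)=O)cc2)o1` is the reference point of this note. In a functional assay on MDA-MB-231 cells (Homo sapiens) for inhibition, read by MTT assay, with a stated time of 24 h, tested at 100 uM (on this read-out lower numbers stand for less inhibition and higher numbers for more inhibition at the one concentration tested (going by the name of the read-out)), compound 1 gives 21.5%, the highest of the three numbers in hand. Compound 2 `COc1ccc(/C=N/NC(=O)c2ccc(O[C@@H]3O[C@H](CO)[C@@H](O)[C@H](O)[C@H]3O)cc2)cc1` gives 11.3% and compound 3 `N#Cc1cccc(/C=N/NC(=O)c2ccc(O[C@@H]3O[C@H](CO)[C@@H](O)[C@H](O)[C@H]3O)cc2)c1` gives 6.17%; both sit on another core, and both lie beyond the scatter below compound 1 without describing its part of the series. For the measured compounds named here, the one measured step, a number 5.1 percentage points lower from compound 2 to compound 3 (within the scatter), stays within the scatter and concerns a place that compound 4 leaves untouched.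

Compound 4 `CC(=O)OC[C@H]1O[C@@H](Oc2ccc(-c3nnc(C4CCCCC4)o3)cc2)[C@H](OC(C)=O)[C@@H](OC(C)=O)[C@@H]1OC(C)=O` differs from compound 1 by cyclohexyl in place of pentyl on an aromatic carbon. Going by the values given here, no measured pair exchanges pentyl for cyclohexyl or alters the group on the five-membered aromatic ring, so nothing in hand sets a direction for this change. The expectation is therefore no movement beyond the scatter, with a number 0.5 percentage points higher from compound 1 to compound 4 (within the scatter) estimated near zero. Compound 4 is expected to give about 22%, in the range 8% to 38%.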

Compound 4, a percentage reported as inhibition, at one concentration (the size of the read-out at that concentration, not a potency): 11.6%
Estimate against measurement, compound 4: 10.4 percentage points above; low and high end bracket the measured number.
By their numbers in this assay, from the lowest: compounds 3, 2, 4 and 1 (each within the scatter of the next, the first and the last beyond it).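

In this assay, for the compounds shown here, the exchange of pentyl for cyclohexyl gives the first measured step at this aromatic carbon of the five-membered ring, a number 9.9 percentage points lower from compound 1 to compound 4 (within the scatter). On the core of compound 1, an open chain and a six-membered carbon ring at this place therefore cannot be told apart at the one concentration tested, and this single pair sets no direction for the change. No available evidence bears on this step, and nothing can be said about what underlies it.

Open, from the compounds shown here alone, is whether an amine, a carboxylic acid or a chain longer than pentyl at this aromatic carbon would move the number beyond the scatter. Also open, going by these compounds, is how pentyl and cyclohexyl compare when the acetyl groups on the sugar are replaced by free hydroxyl groups.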